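From 4-Bromophenyl to 1H-Indol-2-yl on a Carbonyl Carbon

A few compounds are considered here, and "the series" means these few. Any claim that something is new, unique, unknown or untested is made for them only; others in the source may bear on it.

Of the compounds shown here, two have been measured in an ADME assay on cells (Fibroblast) for cytotoxicity; a higher number here means a weaker inhibitor, a lower number a stronger inhibitor. Compound 1 (`O=C(CCCSC[C@H](NC(=O)c1ccc(Br)cc1)C(=O)NCc1ccccc1)NO`) gives 830 nM, while compound 2 (`O=C(CCCCC[C@H](NC(=O)c1ccc(Br)cc1)C(=O)NCc1ccccc1)NO`) gives 5860 nM, the higher of the two numbers. Among the measured compounds shown here, the single measured step, a 7.1-fold higher number from compound 1 to compound 2 (0.85 log units; beyond the scatter), is modest but beyond the scatter. It places 4-(hydroxycarbamoyl)butyl where (3-(hydroxycarbamoyl)propyl)sulfanyl stood on a saturated chain carbon.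

Compound 3 (`O=C(CCCCC[C@H](NC(=O)c1cc2ccccc2[nH]1)C(=O)NCc1ccccc1)NO`) keeps that chain from compound 2 and changes another part of the molecule, with 1H-indol-2-yl in place of 4-bromophenyl on a carbonyl carbon. The measured step therefore bears on this change only indirectly. For the measured compounds named here, it shows how far this assay moved for a change on the chain, but no measured pair shows what a change on the carbonyl carbon does. With no such evidence, the starting point is the 5860 nM of compound 2, and no step beyond the scatter is expected. The expected change is a 1.5-fold lower number from compound 2 to compound 3 (0.17 log units; within the scatter). Compound 3 is estimated at 4000 nM, with an expected range from 1200 nM to 13000 nM.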

Compound 3, half-maximal inhibitory concentration: 1260 nM
Beside the measured number, compound 3's estimate is 3.2-fold (0.50 log units) above it; the measured number falls inside the stated range.
By their numbers in this assay, from the lowest: compounds 1 and 3 (each within the scatter of the next); then compound 2.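

In this assay, the carbonyl carbon whose other neighbour is the amide-type nitrogen now has a measured step of its own: 1H-indol-2-yl in place of 4-bromophenyl gives a 4.7-fold lower number from compound 2 to compound 3 (0.67 log units; beyond the scatter), so a change at this place, and not only one on the chain, moves the number beyond the scatter. Set beside the earlier change on the chain, a 7.1-fold higher number from compound 1 to compound 2 (0.85 log units; beyond the scatter), this step runs the other way, with the number falling here where it rose there, and each of the two is modest. The exchange replaces a single six-membered aromatic ring with a five-membered and a six-membered aromatic ring and adds a hydrogen-bond donor, but no measurement available here says which of these differences, if any, lies behind the step.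

The compounds shown leave open whether the ring nitrogen with its hydrogen matters, a question that a 1-methylindol-2-yl group or an unsubstituted phenyl on the same carbonyl carbon could address. They also leave open whether 1H-indol-2-yl gives a step of similar size when paired with the (3-(hydroxycarbamoyl)propyl)sulfanyl chain.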